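This account rests on a few compounds, and the source may have more. Where it says the series, first, only, none or still open, it means among the compounds named here.

Measured in a functional assay on MCF7 cells (Homo sapiens) for cytotoxicity, read by MTT assay, with a stated time of 48 h; a lower number here means a stronger inhibitor, a higher number a weaker inhibitor:
Compound 1 `COc1cc(-c2nnc3n2NC(c2cccs2)C(C(=O)c2ccccc2)S3)cc(OC)c1OC` sits at the limit of the assay, > 100000 nM, not at a number.
Compound 2 `COc1cc(-c2nnc3n2NC(c2ccco2)C(C(=O)c2ccc(C)cc2)S3)cc(OC)c1OC` likewise sits at the limit, > 100000 nM.
Compound 3 `COc1ccc(C(=O)C2Sc3nnc(-c4cc(OC)c(OC)c(OC)c4)n3NC2c2cccs2)cc1` gives 49500 nM.

Compound 2 thus stands at the limit, alongside compound 1, with only compound 3 yielding a number; 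
 the limit of > 100000 nM in this assay, at which 2 of the 3 values shown sit, describes where most of the series sits. Compound 4 `COc1cc(-c2nnc3n2NC(c2ccco2)C(C(=O)c2ccc(O)cc2)S3)cc(OC)c1OC` differs from compound 2 as follows: hydroxy in place of methyl on an aromatic carbon. Among the measured compounds shown here, the only measured step, an at least 2.0-fold lower number from compound 1 to compound 3 (0.30 log units; that floor lies within the scatter), concerns methoxy in place of hydrogen, a different change, and its floor lies within the scatter. For the measured compounds named here, no measured step bears on hydroxy in place of methyl. The expectation is therefore no step beyond the scatter, an at least 1.1-fold lower number from compound 2 to compound 4 (0.04 log units; that floor lies within the scatter), with a limit again the likeliest outcome. Compound 4 is estimated at 90000 nM, within 30000 nM to 250000 nM.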

Compound 4, half-maximal inhibitory concentration: 88900 nM
Beside the measured number, compound 4's estimate is 1.0-fold (0.01 log units) above it; low and high end bracket the measured number.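

Replacing methyl with hydroxy on the six-membered aromatic ring, para to a large group, gives a numerical reading for compound 4 in this assay: an at least 1.1-fold lower number from compound 2 to compound 4 (0.05 log units; that floor lies within the scatter). Compound 2 gives > 100000 nM, a limit and not a number, so the step is only a floor. Limits still account for part of the series: the limit of > 100000 nM in this assay, at which 2 of the 4 values shown sit.

As far as these compounds go, it remains open whether an amine or a carboxylic acid at this position would give a step beyond the scatter. From the compounds shown here alone, the same hydroxy-for-methyl change also remains untested on other versions of the shared core.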